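The source may report more compounds than this note shows. Statements on the series, on what has been measured and on what is new or still open speak of the compounds shown alone.

Measured so far:
Compound 1 `COc1ccc(-c2cc(/C=C/C(=O)c3ccc(N)cc3)[nH]n2)cc1`: 1240 nM
Compound 2 `COc1cc(-c2cc(/C=C/C(=O)c3ccc(N)cc3)[nH]n2)cc(OC)c1OC`: 1420 nM
Compound 3 `COc1cc(-c2cc(/C=C/C(=O)c3ccc(F)c(F)c3)[nH]n2)cc(OC)c1OC`: "not determined" (no result reported)

In a functional assay on U-251 cells (Homo sapiens) for inhibition, read by sulforhodamine B assay, with a stated time of 48 h (a lower number here means a stronger inhibitor of growth, a higher number a weaker inhibitor of growth), compound 2 gives 1420 nM. Compound 2 carries three methoxy groups where compound 1 carries a single one; in this assay compound 1 gives 1240 nM, and the two numbers lie within the scatter of each other, so they cannot be told apart. For compound 3 the result in this assay is "not determined" (no result reported), so no number is available for it.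

Compound 4 `COc1ccc(-c2cc(/C=C/C(=O)c3ccc(N)cc3)[nH]n2)cc1OC` is not yet measured. Its difference from compound 2 is hydrogen in place of methoxy on an aromatic carbon. Since compound 1 and compound 2 agree despite a larger difference in methoxy groups, no step beyond the scatter is expected here. The step from compound 2 to compound 4 in this assay is estimated at a 1.1-fold lower number from compound 2 to compound 4 (0.04 log units; within the scatter). Compound 4 is therefore expected to give about 1300 nM, within 600 nM to 2800 nM.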

Compound 4, concentration for 50% growth inhibition: 1740 nM
The estimate for compound 4 lay 1.3-fold (0.13 log units) below the measured number; measured number inside the range.
By their numbers in this assay, from the lowest: compounds 1, 2 and 4 (each within the scatter of the next).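

In this assay the swap of hydrogen for methoxy gives a 1.2-fold higher number from compound 2 to compound 4 (0.09 log units; within the scatter) and the swap of methoxy for hydrogen gives a 1.4-fold higher number from compound 1 to compound 4 (0.15 log units; within the scatter) and so both single changes stay within the scatter. Among the compounds shown here, these are the first comparisons of compounds that differ in only one place, and they show that one methoxy group more or fewer on this aromatic ring does not measurably alter growth inhibition here. Nothing measured gives a reason for this result.

Still open, from the compounds shown here alone, is whether a group other than methoxy on this aromatic carbon, such as hydroxyl or ethoxy, would give a step beyond the scatter.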